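This account rests on a few compounds, and the source may have more. Where it says the series, first, only, none or still open, it means among the compounds named here.

In a functional assay (brain) for inhibition, with Rattus norvegicus as the target (a higher number here means a weaker inhibitor, a lower number a stronger inhibitor), compound 2 `COc1cc2c(cc1O)C(=O)CC(C(N)=O)O2` stands only at a limit, > 300000 nM. The next change, to compound 3 `COc1cc2c(cc1O)C(=O)CC(C(=O)NCc1ccccc1)O2`, is benzyl in place of hydrogen on an amide-type nitrogen. Compound 1 `CCCCNC(=O)C1CC(=O)c2cc(O)c(OC)cc2O1`, with butyl on that nitrogen, gives 177000 nM. Within the data shown here, the only measured step at this place is an at least 1.6-fold higher number from compound 1 to compound 2 (0.22 log units; that floor lies within the scatter). Read in reverse, it points to a modest move toward a lower number on replacing the amide hydrogen, though butyl is not benzyl and the evidence is thin. The estimated step is an at least 2.0-fold lower number from compound 2 to compound 3 (0.30 log units; that floor lies within the scatter). Compound 3 is expected at 150000 nM, with an estimated range of 60000 nM to 300000 nM.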

Compound 3, half-maximal inhibitory concentration: > 300000 nM
Compound 3: only a limit was reported (the forecaster's own chance of this, stated with the estimate: 35%); middle value at least 2.0-fold (0.30 log units) from the limit.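

Benzyl on the amide-type nitrogen does not bring the series to a readable value in this assay: compound 3 is reported only as a limit, > 300000 nM. Exchanging the butyl of compound 1 for benzyl gives an at least 1.6-fold higher number from compound 1 to compound 3 (0.22 log units; that floor lies within the scatter), and the step between the two limits cannot be read. Compound 1 therefore remains the only readable value at this position: the limit of > 300000 nM in this assay, at which 2 of the 3 values shown sit.

Open, as far as these compounds go, is whether a longer straight chain on this nitrogen would give a second readable value. Also open, from the compounds shown here alone, is what a terminal amine or carboxylic acid on the butyl chain would do.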